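The source may hold more compounds than are shown below. What is called first, only, known or untested is meant among the compounds shown, and "the series" means these compounds.

Measured so far in an assay for inhibition of high affinity nerve growth factor receptor (Homo sapiens), read by HTRF, with a stated time of 30 min, in the presence of a further agent that is not named here; on this read-out higher numbers stand for weaker inhibition and lower numbers for stronger inhibition: compound 1 `Cc1cc(Nc2nc(NCc3ccc(Cl)cc3)nc3ccccc23)n[nH]1` at 380 nM; compound 2 `Cc1cc(Nc2nc(NCc3c(F)cccc3F)nc3ccccc23)n[nH]1` at 160 nM; compound 3 `Cc1cc(Nc2nc(NCc3ccc(F)c(F)c3)nc3ccccc23)n[nH]1` at 74 nM.

Compound 3 gives the lowest number of the three, with a 2.2-fold lower number from compound 2 to compound 3 (0.33 log units; beyond the scatter) and a 5.1-fold lower number from compound 1 to compound 3 (0.71 log units; beyond the scatter), both beyond the scatter. Compound 4 `Cc1cc(Nc2nc(NCc3cc(F)c(F)c(F)c3)nc3ccccc23)n[nH]1` differs from compound 3 by fluoro in place of hydrogen on an aromatic carbon. Among the measured compounds shown here, no measured step adds a third fluoro to a ring already carrying two; the nearest evidence is that moving from 4-chlorophenyl to a difluorophenyl lowered the number in both a 2.4-fold lower number from compound 1 to compound 2 (0.38 log units; beyond the scatter) and a 5.1-fold lower number from compound 1 to compound 3 (0.71 log units; beyond the scatter), while the difluoro pattern itself mattered, as a 2.2-fold lower number from compound 2 to compound 3 (0.33 log units; beyond the scatter) shows. A further fluoro is therefore expected to leave compound 4 near compound 3, the expected step of a 1.2-fold lower number from compound 3 to compound 4 (0.09 log units; within the scatter) being within or at the edge of the scatter. Compound 4 is estimated at 60 nM, in the range 25 nM to 150 nM.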

Compound 4, half-maximal inhibitory concentration: 870 nM
Compound 4: middle estimate off by 15-fold (1.16 log units), on the low side; the measured number lies above the stated range.
By their numbers in this assay, from the lowest: compound 3; then compound 2; then compound 1; then compound 4.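

Fluoro in place of hydrogen on the 3,4-difluorophenyl ring, ortho to a fluoro group and meta to a large group, is far from a neutral change here: the series shows a 12-fold higher number from compound 3 to compound 4 (1.07 log units; beyond the scatter) as its largest step. The 3,4,5-trifluorophenyl group also trails the other two aryl groups, with a 5.4-fold higher number from compound 2 to compound 4 (0.74 log units; beyond the scatter) and a 2.3-fold higher number from compound 1 to compound 4 (0.36 log units; beyond the scatter) on record, so the fluoro count alone does not order these rings. Nothing measured here explains the rise.

Going by these compounds, it remains open whether the rise is specific to fluoro or follows any group at this place. A methyl or methoxy group there would separate the two.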